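Dichloro Substitution on the Carbamate Aryl Group

A few compounds are considered here, and "the series" means these few. Any claim that something is new, unique, unknown or untested is made for them only; others in the source may bear on it.

Measured compounds:
Compound 1 `COc1nc(C)c(Nc2nc(Cl)cn([C@H](COC(=O)c3ccccc3)C3CC3)c2=O)cc1C` gives 1.5 nM in an assay on frontal cortex for displacement of a labelled ligand from corticotropin-releasing factor receptor 1 (Rattus norvegicus), with a stated time of 2 h; a higher number here means a weaker inhibitor, a lower number a stronger inhibitor.
Compound 2 `COc1nc(C)c(Nc2nc(Cl)cn([C@H](COC(=O)Nc3ccccc3)C3CC3)c2=O)cc1C` gives 1.5 nM in this assay.
Compound 3 `COc1nc(C)c(Nc2nc(Cl)cn([C@H](COC(=O)Nc3ccccc3Cl)C3CC3)c2=O)cc1C` gives 1.5 nM in this assay.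

Compound 2 stands level with both neighbours: the step of no change at the digits printed from compound 1 to compound 2 (within the scatter) and the step of no change at the digits printed from compound 2 to compound 3 (within the scatter) both stay within the scatter, as does the step of no change at the digits printed from compound 1 to compound 3 (within the scatter). Swapping the phenyl on the carbonyl carbon for anilino, or adding a chloro to that anilino ring, left the numbers untouched.

Compound 4 `COc1nc(C)c(Nc2nc(Cl)cn([C@H](COC(=O)Nc3cc(Cl)cc(Cl)c3)C3CC3)c2=O)cc1C` takes the change (3,5-dichlorophenyl in place of phenyl on an amide-type nitrogen). Within the data shown here, the most relevant measured step is the one from compound 2 to compound 3, where one chloro entered the aryl ring with no effect; compound 4 carries two chloro groups on that ring instead of one. Among the measured compounds shown here, nothing measured so far shows the aryl group on the carbamate nitrogen mattering, so the expected step of no change at the digits printed from compound 2 to compound 4 (within the scatter) is none beyond the scatter. The estimate for compound 4 is therefore 1.5 nM, with a range from 0.6 nM to 4.5 nM. A second chloro on that ring has not been measured in any compound here; the range is kept somewhat wide.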

Compound 4, half-maximal inhibitory concentration: 1.7 nM
Estimate against measurement, compound 4: 1.1-fold (0.05 log units) below; the range from low to high includes it.
By their numbers in this assay, from the lowest: compounds 1, 2, 3 and 4 (each within the scatter of the next).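

In this assay, 3,5-dichlorophenyl in place of phenyl on the amide-type nitrogen gives a 1.1-fold higher number from compound 2 to compound 4 (0.05 log units; within the scatter), and the same group in place of 2-chlorophenyl gives a 1.1-fold higher number from compound 3 to compound 4 (0.05 log units; within the scatter). Among these compounds, this position therefore accepts a second chloro and a different chloro pattern on the ring, which the single 2-chlorophenyl example could not show. The wider change on the carbonyl carbon, (3,5-dichlorophenyl)amino in place of phenyl, gives a 1.1-fold higher number from compound 1 to compound 4 (0.05 log units; within the scatter), so all four compounds remain level, and nothing available explains why these changes leave the number in place.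

Every group shown at this position carries a phenyl ring, bare or with chloro, so it remains open whether the flat result would survive a ring bearing an amine or a carboxylic acid, or a longer alkyl chain in place of the ring. On these data alone, it is also open whether the whole carbamate is needed at all, since a plain hydroxyl on that carbon chain would test what the side arm contributes to the value shared by these compounds.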